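A few compounds are considered here, and "the series" means these few. Any claim that something is new, unique, unknown or untested is made for them only; others in the source may bear on it.

Measured in an ADME assay on L1210 cells (Mus musculus) for cytotoxicity, with a stated time of 48 h; on this read-out lower numbers stand for stronger inhibition and higher numbers for weaker inhibition:
- compound 1 `CC1=CCC[C@](C)(CC/C(C)=C/CC2=C(O)C(=O)C=C(N[C@@H](CO)C(=O)O)C2=O)[C@@H]1C`: > 10 ug/mL
- compound 2 `C=C1[C@H](C)CCC[C@]1(C)CC/C(C)=C/CC1=C(O)C(=O)C=C(OC)C1=O`: 2.4 ug/mL
- compound 3 `C=C1[C@H](C)CCC[C@]1(C)CC/C(C)=C/CC1=C(O)C(=O)C=C(N[C@@H](CO)C(=O)O)C1=O`: > 10 ug/mL

Compound 1 stands at the limit of > 10 ug/mL in this assay, at which 2 of the 3 values shown sit. Going by these compounds, this is a limit and not a number, so its exact place on the scale is unknown.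

Compound 4 `CC1=CCC[C@](C)(CC/C(C)=C/CC2=C(O)C(=O)C=C(N[C@H](C(=O)O)C(C)C)C2=O)[C@@H]1C` keeps the core of compound 1 and changes one group: isopropyl in place of hydroxymethyl on a saturated chain carbon bound to an amine nitrogen and a carbonyl carbon. The whole substituent therefore goes from (1-carboxy-2-hydroxyethyl)amino to (1-carboxy-2-methylpropyl)amino.

Going by the values given here, no measured step makes this exact change. The closest is an at least 4.1-fold higher number from compound 2 to compound 3 (0.61 log units; beyond the scatter), where (1-carboxy-2-hydroxyethyl)amino took the place of methoxy. The other, a step that the two limits leave unreadable from compound 1 to compound 3, offers no size to build on.

Compound 4 still carries a closely related substituent, so a weak result like that of compound 3 in an at least 4.1-fold higher number from compound 2 to compound 3 (0.61 log units; beyond the scatter) is expected, with no clear direction relative to compound 1. The expected change is a step that the limit leaves unreadable from compound 1 to compound 4, and a report of only a limit would be unsurprising. For compound 4 the estimated value is 12 ug/mL, with an expected range of 5 ug/mL to 30 ug/mL.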

Compound 4, half-maximal inhibitory concentration: 3.4 ug/mL
Compound 4: middle estimate off by 3.5-fold (0.55 log units), on the high side; measured number outside the range, below it.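

In this assay, the carbon bound to the amine nitrogen and the carbonyl carbon proves to be a place where a single group can move the read-out: isopropyl in place of hydroxymethyl gives an at least 2.9-fold lower number from compound 1 to compound 4 (0.46 log units; beyond the scatter). The earlier compounds shown here showed only a weak result for the (1-carboxy-2-hydroxyethyl)amino substituent, whereas compound 4 shows that carrying a carboxy-bearing amino substituent does not by itself keep the number at the limit. The full size of this step cannot be read, since the value of compound 1 is only a limit: the limit of > 10 ug/mL in this assay, at which 2 of the 4 values shown sit.

Going by these compounds, whether the gain comes from losing the hydroxyl or from adding the branched carbons stays open, and a plain methyl or a benzyl group at this carbon would help to separate the two. On these data alone, it is also open whether the same change would act alike on the core of compound 3.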